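A few compounds are considered here, and "the series" means these few. Any claim that something is new, unique, unknown or untested is made for them only; others in the source may bear on it.

Measured so far:
- compound 1, `CCc1nc(-c2ccc(Cl)cc2Cl)c(OC)nc1NC(CC)CC`: 8 nM
- compound 2, `CCCN(CC1CC1)c1nc(CC)c(-c2ccc(Cl)cc2Cl)nc1CC`: 19.2 nM

Both were read in an assay on IMR-32 cells for displacement of a labelled ligand from corticotropin-releasing factor receptor 1 (Homo sapiens), read by scintillation counting, with a stated time of 2 h; on this read-out lower numbers stand for stronger inhibition and higher numbers for weaker inhibition. Going by the values given here, compound 2 gives the higher of the two numbers; compound 1, the only other compound, sits at 8 nM, lower by a margin beyond the usual scatter. Whether the two ethyl groups on the core of compound 2 or the amine substitution pattern accounts for that gap cannot be separated from two compounds alone.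

The next compound, compound 3 with structure `CCc1nc(-c2ccc(Cl)cc2Cl)c(CC)nc1NC(C)CN(C)C`, keeps the core of compound 2 and changes only the amine: (1-((dimethylamino)methyl)ethyl)amino in place of (cyclopropylmethyl)(propyl)amino on an aromatic carbon. Among the compounds with values here, no measured pair shows this particular replacement, so there is no step to lean on. Compound 3 is expected to land near compound 2, with the step of a 1.3-fold higher number from compound 2 to compound 3 (0.11 log units; within the scatter) taken as no change beyond the scatter, leaning slightly weaker. The estimate for compound 3 in this assay is 25 nM, within 6 nM to 100 nM.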

Compound 3, inhibition constant: 489 nM
Estimate against measurement, compound 3: 20-fold (1.29 log units) below; the whole stated range lies below it.
By their numbers in this assay, from the lowest: compound 1; then compound 2; then compound 3.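

In this assay, going by these compounds alone, the amine on this aromatic carbon of the shared core proves far from interchangeable: (1-((dimethylamino)methyl)ethyl)amino in place of (cyclopropylmethyl)(propyl)amino gives a 25-fold higher number from compound 2 to compound 3 (1.41 log units; beyond the scatter) and is the first single-place change, as compound 1 and compound 2 differ in more than one place. The swap removes the three-membered ring and moves from 0 hydrogen-bond donors and 1 acceptor to 1 donor and 2 acceptors, so several features change together and the step cannot be assigned to any one of them. Nothing on hand bears on the reason for a step of this size.

Which feature carries the loss remains open. A hydroxyl group at the end of the chain in place of the dimethylamino group, or a tertiary amine without the chain nitrogen, would help separate these features.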